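The compounds below may be only part of what the source reports. "The series", "measured", "known", "first", "only" and "open" are said of these compounds alone.

Measured so far in a functional assay on COLO 320 cells (Homo sapiens) for cytotoxicity, read by WST assay, with a stated time of 72 h; a lower number here means a stronger inhibitor, a higher number a weaker inhibitor:
compound 1 `O=[N+]([O-])c1ccc(-c2cc(-c3ccc4[nH]ccc4c3)on2)cc1` gives 14000 nM
compound 2 `Fc1ccc(-c2cc(-c3ccc4[nH]ccc4c3)on2)cc1` gives 13900 nM
compound 3 `COc1ccc(-c2cc(-c3cc4ccccc4n3C)on2)cc1` gives a limit, > 100000 nM

Compound 2 stands together with compound 1 at the same level, the step of a 1.0-fold lower number from compound 1 to compound 2 (0.00 log units; within the scatter) showing that exchanging the group on the outer ring left the number where it was. The value of compound 3 is a limit of this assay the limit of > 100000 nM in this assay, at which 1 of the 3 values shown sits, and not a number. Compound 3 also carries a different core, so it offers no single-point comparison with compound 2.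

Compound 4 `COc1ccc(-c2cc(-c3ccc4[nH]ccc4c3)on2)cc1` comes next: methoxy in place of fluoro on an aromatic carbon. Going by the values given here, the one measured step at the same position of the shared core is a 1.0-fold lower number from compound 1 to compound 2 (0.00 log units; within the scatter), which lay within the scatter. Compound 3 carries the methoxy as well, but on another core, so its limit stands apart. The step of a 1.4-fold higher number from compound 2 to compound 4 (0.16 log units; within the scatter) is therefore expected to fall within or close to the scatter, with some allowance toward a weaker number. Compound 4 is estimated at 20000 nM in this assay, with a range from 7000 nM to 60000 nM.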

Compound 4, half-maximal inhibitory concentration: 13500 nM
For compound 4 the middle estimate is 1.5-fold (0.17 log units) above the measured one; low and high end bracket the measured number.
By their numbers in this assay, from the lowest: compounds 4, 2 and 1 (each within the scatter of the next). At a limit, above all of these: compound 3.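

In this assay, the exchange for methoxy gives a 1.0-fold lower number from compound 2 to compound 4 (0.01 log units; within the scatter) and a 1.0-fold lower number from compound 1 to compound 4 (0.02 log units; within the scatter), so neither step leaves the scatter. The earlier step compared only nitro and fluoro; this aromatic carbon, para to a large group, now carries three groups on the shared core with all steps among them within the scatter, including one that enters with a hydrogen-bond acceptor and more heavy atoms than fluoro. No measurement shown gives a reason why the numbers stay level across these groups.

As far as these compounds go, whether an amine, a carboxylic acid or a longer chain at this position would also stay within the scatter remains open. Also open, from the compounds shown here alone, is whether any group at this position can move the number beyond the scatter on the shared core.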